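Notes on a urea-linked series: a methyl step to compound 4

The compounds below may be only part of what the source reports. "The series", "measured", "known", "first", "only" and "open" are said of these compounds alone.

Three measured members share one core and differ only in the aryl group on the amide-type nitrogen. In a functional assay on HepG2 cells (Homo sapiens) for antiproliferative activity, read by MTT assay, with a stated time of 48 h (a lower number here means a stronger inhibitor, a higher number a weaker inhibitor), compound 1 `Cc1ccc(NC(=O)Nc2cccc(CNc3nccnc3Cl)c2)cc1` gives 11500 nM; compound 2 `CCOc1ccc(NC(=O)Nc2cccc(CNc3nccnc3Cl)c2)cc1` gives 7050 nM and compound 3 `Cc1ccc(NC(=O)Nc2cccc(CNc3nccnc3Cl)c2)cc1Cl` gives 11300 nM. Compound 1 stands highest of the three numbers, but both a 1.6-fold lower number from compound 1 to compound 2 (0.21 log units; within the scatter) and a 1.0-fold lower number from compound 1 to compound 3 (0.01 log units; within the scatter) lie within the scatter, as does a 1.6-fold higher number from compound 2 to compound 3 (0.20 log units; within the scatter); the set so far shows no separation at all.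

Compound 4 `Cc1ccc(NC(=O)Nc2cccc(CNc3nccnc3Cl)c2)c(C)c1` differs from compound 1 by methyl in place of hydrogen on an aromatic carbon. The new group sits on an aromatic carbon of a six-membered aromatic ring of carbon only, ortho to a large group and meta to a methyl group, so that 4-methylphenyl becomes 2,4-dimethylphenyl. Among the measured compounds shown here, the nearest precedent is a 1.0-fold lower number from compound 1 to compound 3 (0.01 log units; within the scatter), a substituent entering the same ring of compound 1 without any shift beyond scatter; a 1.6-fold lower number from compound 1 to compound 2 (0.21 log units; within the scatter) was equally small. For the measured compounds named here, no measured step supports a change in this assay for compound 4 beyond the scatter in either direction.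

Compound 4 is therefore expected at 11000 nM, within 5500 nM to 22000 nM. The expected step is a 1.0-fold lower number from compound 1 to compound 4 (0.02 log units; within the scatter), essentially none.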

Compound 4, half-maximal inhibitory concentration: 9290 nM
Estimate against measurement, compound 4: 1.2-fold (0.07 log units) above; measured number inside the range.
By their numbers in this assay, from the lowest: compounds 2, 4, 3 and 1 (each within the scatter of the next).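

In this assay the 2,4-dimethylphenyl compound puts a group on a ring position that carries none in compounds 1 to 3, ortho to a large group and meta to a methyl group, and a 1.2-fold lower number from compound 1 to compound 4 (0.09 log units; within the scatter) shows that methyl is taken up there without a shift beyond the scatter. The other two comparisons stay equally flat, with a 1.2-fold lower number from compound 3 to compound 4 (0.09 log units; within the scatter) and a 1.3-fold higher number from compound 2 to compound 4 (0.12 log units; within the scatter) so that the four compounds still show no separation. No evidence is available that bears on this step.

As far as these compounds go, whether an amine or a carboxylic acid at this same position would move the number beyond the scatter remains open. All four compounds also keep the shared core unchanged, so the outcome of an amine in place of its chloro group is open too.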